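Swapping the amide aryl group for a methoxystyryl chain

A few compounds are considered here, and "the series" means these few. Any claim that something is new, unique, unknown or untested is made for them only; others in the source may bear on it.

Measured compounds in a functional assay on HepG2 cells (Homo sapiens) for cytotoxicity, read by MTT assay, with a stated time of 72 h; a lower number here means a stronger inhibitor, a higher number a weaker inhibitor:
- compound 1 `CCc1ccc(C(=O)NC[C@H]2c3[nH]c4ccccc4c3C[C@H]3[C@H]4c5[nH]c6ccccc6c5C[C@@H]([C@H](C#N)N23)N4C)cc1`: 570 nM
- compound 2 `CN1[C@@H]2c3[nH]c4ccccc4c3C[C@H]1[C@H](C#N)N1[C@@H](CNC(=O)c3cc4ccccc4s3)c3[nH]c4ccccc4c3C[C@@H]21`: 300 nM
- compound 3 `CN1[C@@H]2c3[nH]c4ccccc4c3C[C@H]1[C@H](C#N)N1[C@@H](CNC(=O)c3cc4ccccc4o3)c3[nH]c4ccccc4c3C[C@@H]21`: 280 nM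

All three share one core and differ only in the group attached to the amide carbonyl. Compound 3 gives the lowest of the three numbers, but compound 2 sits within the usual scatter of it, so the two cannot be told apart. Going by the values given here, the only step beyond the scatter is a 2.0-fold lower number from compound 1 to compound 3 (0.31 log units; beyond the scatter), a modest gain from a flat aryl group to a fused two-ring group; a 1.9-fold lower number from compound 1 to compound 2 (0.28 log units; within the scatter) and a 1.1-fold lower number from compound 2 to compound 3 (0.03 log units; within the scatter) stay within the scatter.

Compound 4 `COc1ccc(/C=C/C(=O)NC[C@H]2c3[nH]c4ccccc4c3C[C@H]3[C@H]4c5[nH]c6ccccc6c5C[C@@H]([C@H](C#N)N23)N4C)cc1` carries the change (2-(4-methoxyphenyl)ethenyl in place of 1-benzofuran-2-yl on a carbonyl carbon). The entering group is a single carbon ring like that of compound 1, held away from the carbonyl by a double bond, rather than a fused two-ring group. Among the compounds with values here, no measured step covers this exact change; the nearest guide is the modest step between compound 1 and compound 3. Compound 4 is therefore expected to land between those two, with a step of a 1.6-fold higher number from compound 3 to compound 4 (0.21 log units; within the scatter) that is small and likely within the scatter. The estimate for compound 4 is 450 nM, expected to fall between 200 nM and 1000 nM.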

Compound 4, half-maximal inhibitory concentration: 2140 nM
Beside the measured number, compound 4's estimate is 4.8-fold (0.68 log units) below it, outside the stated range (above it).
By their numbers in this assay, from the lowest: compounds 3, 2 and 1 (each within the scatter of the next, the first and the last beyond it); then compound 4.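

In this assay, the group on this carbonyl carbon matters more than the first three compounds showed: 2-(4-methoxyphenyl)ethenyl gives a 7.6-fold higher number from compound 3 to compound 4 (0.88 log units; beyond the scatter) and a 7.1-fold higher number from compound 2 to compound 4 (0.85 log units; beyond the scatter), steps well beyond the scatter. Having a single carbon ring does not by itself set the number, as compound 1 also has one, yet there is still a 3.8-fold higher number from compound 1 to compound 4 (0.57 log units; beyond the scatter). No measurement here explains why this group gives a weaker result.

Going by these compounds, compound 4 brings in its double bond and its methoxy group together, so the share of each in this weakening remains open. A plain 4-methoxyphenyl group on the carbonyl carbon, or a saturated 2-(4-methoxyphenyl)ethyl chain in place of the ethenyl one, would help separate the two.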